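Chloro for methoxy in a series at its limit

The compounds below may be only part of what the source reports. "The series", "measured", "known", "first", "only" and "open" are said of these compounds alone.

In a toxicity assay on THP-1 cells (Homo sapiens) for inhibition (on this read-out higher numbers stand for lower toxicity in this test and lower numbers for higher toxicity in this test), compound 1 `COc1ccc(-c2cnc(NC(=O)c3ncc[nH]3)n2C)cc1` gives > 100000 nM as a limit of the assay, not as a number. Compound 2 `COc1ccc(-c2cnc(NC(=O)c3cnco3)n2C)cc1` gives > 100000 nM as a limit too. Compound 3 `COc1ccc(-c2cnc(NC(=O)c3cccc(F)c3)n2C)cc1` gives > 100000 nM as a limit too. The measured series stands at the limit of > 100000 nM in this assay, at which 3 of the 3 values shown sit, and cannot be ranked on these numbers.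

Compound 4 `Cn1c(-c2ccc(Cl)cc2)cnc1NC(=O)c1ncc[nH]1` carries chloro in place of methoxy on an aromatic carbon, para to a large group chloro in place of methoxy on an aromatic carbon and is otherwise the same as compound 1.

The measured steps all concern the group on the carbonyl carbon: a step that the two limits leave unreadable from compound 1 to compound 2 for 1,3-oxazol-5-yl in place of 1H-imidazol-2-yl, a step that the two limits leave unreadable from compound 1 to compound 3 for 3-fluorophenyl in place of 1H-imidazol-2-yl, and a step that the two limits leave unreadable from compound 2 to compound 3 for 3-fluorophenyl in place of 1,3-oxazol-5-yl. None of them touches the methoxy, and none has a readable size.

With the limit of compound 1 at > 100000 nM as the only anchor, no step beyond the scatter is expected in this assay and no direction can be given. The estimated step is a number no higher from compound 1 to compound 4 (the limit leaves the size open) and may itself stay unreadable. For compound 4 the estimated value is 100000 nM with an expected range of 40000 nM to 150000 nM and a reading at the limit is the likeliest outcome.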

Compound 4, half-maximal cytotoxic concentration in the THP-1 assay: 52000 nM
For compound 4 the middle estimate is 1.9-fold (0.28 log units) above the measured one; the measured number falls inside the stated range.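

Compound 4 is the only one of the four compounds with a readable number in the THP-1 assay, which makes the position para to a large group the only place shown where a change leaves the limit: the limit of > 100000 nM in the THP-1 assay, at which 3 of the 4 values shown sit.

The size of that change stays small on the numbers available, with an at least 1.9-fold lower number from compound 1 to compound 4 (0.28 log units; that floor lies within the scatter), so chloro in place of methoxy cannot be called a real shift in toxicity here, though compound 1 is only a limit and the true step may be larger.

The clearer effect of the same change is in a physicochemical assay for solubility, read by nephelometry, measured as kinetic solubility, at pH 6.5 (a higher number here means a more soluble compound, a lower number a less soluble compound), where it lies beyond the scatter: the measured solubility of compound 1, 6.3 ug/mL, and of compound 4, 25 ug/mL, a 4.0-fold higher number (0.60 log units; beyond the scatter)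

In the physicochemical assay compound 1 gives 6.3 ug/mL and compound 4 gives 25 ug/mL.

As far as these compounds go, it remains open whether chloro in place of methoxy would give the same two results with 1,3-oxazol-5-yl or 3-fluorophenyl on the carbonyl carbon, as in compound 2 and compound 3. From the compounds shown here alone, it also remains open how other groups at this position, such as fluoro, trifluoromethyl, an amine or a carboxylic acid, would read in the THP-1 assay and in the physicochemical assay.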